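Swapping an Acid Ester for Benzyl on the Core

The source may hold more compounds than are shown below. What is called first, only, known or untested is meant among the compounds shown, and "the series" means these compounds.

Compound 1 `Cc1c(C)c2c(c(C)c1OC(=O)CCC(=O)O)CCC(C)(COc1ccc(/C=C3\SC(=O)NC3=O)cc1)O2` shares its core with compound 2 `CC(C)=CCOc1c(C)c(C)c2c(c1C)CCC(C)(COc1ccc(/C=C3\SC(=O)NC3=O)cc1C)O2` and compound 3 `CC(C)=CCOc1c(C)c(C)c2c(c1C)CCC(C)(COc1ccc(/C=C3\SC(=O)NC3=O)cc1-c1ccc(F)cc1)O2`. In a functional assay on MCF7 cells (Homo sapiens), tested at 2.5 uM (on this read-out lower numbers stand for a stronger effect and higher numbers for a weaker effect at the one concentration tested), compound 1 gives 115%, the highest of the three numbers. Compound 2 gives 89% and compound 3 gives 87%, each beyond the scatter from compound 1. Going by the values given here, the one measured step, a number 2 percentage points lower from compound 2 to compound 3 (within the scatter), concerns a different position and offers little guidance here. Compound 4 `Cc1c(C)c2c(c(C)c1OCc1ccccc1)CCC(C)(COc1ccc(/C=C3\SC(=O)NC3=O)cc1)O2` differs from compound 1 by benzyl in place of (2-carboxyethyl)carbonyl on an oxygen on an aromatic ring. Among the compounds with values here, no measured step covers this change directly; the only hint is that compound 2, which also lacks the (2-carboxyethyl)carbonyl, gives 89%, though compound 2 is not a single-change relative of compound 1. The step in this assay is therefore expected to be a number 20 percentage points lower from compound 1 to compound 4 (beyond the scatter), a modest fall. Compound 4 is expected to give 95%, between 75% and 115%.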

Compound 4, a percentage reported as activity, at one concentration (the size of the read-out at that concentration, not a potency): 85%
Compound 4: the middle estimate sits 10 percentage points above what was measured, and the stated range covers the measured number.
By their numbers in this assay, from the lowest: compounds 4, 3 and 2 (each within the scatter of the next); then compound 1.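

In this assay, going by these compounds alone, the change on this oxygen on an aromatic ring gives a number 30 percentage points lower from compound 1 to compound 4 (beyond the scatter), the first reading of a single change at this position. The heavy-atom count stays at 7, so the step comes with a swap of a chain carrying a hydrogen-bond donor and acceptors for an aromatic ring of carbon only. No measurement shown bears on the cause of this step. Still open, as far as these compounds go, is whether the loss of the acid or the arrival of the ring matters more, and how an amine on a longer chain would read on this oxygen.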